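From Chloro to Amino: One Swap on Compound 2

The compounds below may be only part of what the source reports. "The series", "measured", "known", "first", "only" and "open" are said of these compounds alone.

In an ADME assay on L6 cells (Rattus norvegicus) for cytotoxicity, read by resazurin assay, with a stated time of 72 h (a higher number here means a weaker inhibitor, a lower number a stronger inhibitor), compound 1 (`N=C(N)c1cccc(OCc2cccc([N+](=O)[O-])c2)c1`) gives 78900000 nM while compound 2 (`N=C(N)c1ccc(COc2ccc(Cl)cc2)cc1`) gives 20700000 nM as its reading. Compound 2 therefore holds the lower of the two numbers, and the gap between them lies beyond the usual scatter of repeat measurements. The two compounds differ in more than one place, so that gap cannot be assigned to any single group.

The next compound, compound 3 (`N=C(N)c1ccc(COc2ccc(N)cc2)cc1`), keeps the core of compound 2 and changes one group: amino in place of chloro on an aromatic carbon. For the measured compounds named here, no measured pair shows what this swap does in this assay so any forecast must stay loose. Going by the values given here, the only guide is the span of the two readings so far, with compound 1 at 78900000 nM as the higher one. A modest rise is expected, although a result within the scatter would be no surprise. The estimated change a 2.2-fold higher number from compound 2 to compound 3 (0.34 log units; beyond the scatter) points toward a weaker inhibitor. The estimated value for compound 3 is 45000000 nM (expected range 14000000 nM to 140000000 nM).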

Compound 3, half-maximal inhibitory concentration: > 271000000 nM
Compound 3: only a limit was reported; the forecaster's own chance of this, stated with the estimate: 15%; middle value at least 6.0-fold (0.77 log units) from the limit.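

For the compounds shown here, putting amino in place of chloro, on an aromatic carbon of a six-membered aromatic ring of carbon only and para to a large group, gives an at least 13-fold higher number from compound 2 to compound 3 (1.11 log units; beyond the scatter), the first reading of a single change in this assay. For compound 3 the reported reading is a limit and not a number, so this step marks only the smallest size the change can have: the limit of > 271000000 nM in this assay, at which 1 of the 3 values shown sits. The swap trades one heavy atom for one heavy atom and adds a hydrogen-bond donor and a hydrogen-bond acceptor, which shows that a change this small at this position can carry the reading far beyond the scatter, something compound 1 could not show, as it differs from compound 2 in more than one place.

Since compound 3 gives no exact number and only this one swap is shown, it remains open whether the step comes from losing chloro or from gaining amino. A hydroxyl group, a methyl group or a fluorine atom at the same position could help separate the two, and the same swap on the core of compound 1 would show whether the step carries over to another core.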